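This account rests on a few compounds, and the source may have more. Where it says the series, first, only, none or still open, it means among the compounds named here.

Of the compounds shown here, three built on one shared core have been measured in a physicochemical assay for solubility, in phosphate buffer, measured as kinetic solubility, with a stated time of 1 h, at pH 7.4; a lower number here means a less soluble compound, a higher number a more soluble compound. Compound 1 `COc1ccc2nc(C)cc(OCC(=O)NCc3cc(C)cc(C)c3)c2c1` gives 92000 nM. Compound 2 `COc1ccc2nc(C)cc(OCC(=O)Nc3cc(C)ccc3C)c2c1` gives 45500 nM, and the step of a 2.0-fold lower number from compound 1 to compound 2 (0.31 log units; beyond the scatter) records 2,5-dimethylphenyl in place of 3,5-dimethylbenzyl on the amide-type nitrogen. Compound 3 `COc1ccc2nc(C)cc(OCC(=O)Nc3cc(C)c(OC)c(C)c3)c2c1` gives 17000 nM, the lowest number of the three; compound 2 stands nearest to it and compound 1 furthest. Among the measured compounds shown here, no single step connects compound 2 and compound 3, so their values can only be set side by side.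

Compound 4 `COc1ccc2nc(C)cc(OCC(=O)Nc3cc(C)c(F)c(C)c3)c2c1` differs from compound 3 by fluoro in place of methoxy on an aromatic carbon, ortho to two methyl groups and para to a large group. For the measured compounds named here, none of the measured steps alters a group at this place; the only measured step, a 2.0-fold lower number from compound 1 to compound 2 (0.31 log units; beyond the scatter), concerns the link between the amide nitrogen and the aryl ring and offers no direct guide. Going by the values given here, with no closer precedent, the expected step of a 1.2-fold lower number from compound 3 to compound 4 (0.08 log units; within the scatter) is small and not beyond the scatter, in either direction. Compound 4 is therefore expected to give 14000 nM in this assay, with a range from 5000 nM to 40000 nM.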

Compound 4, solubility: 31500 nM
Compound 4: middle estimate off by 2.3-fold (0.35 log units), on the low side; low and high end bracket the measured number.
By their numbers in this assay, from the lowest: compounds 3, 4 and 2 (each within the scatter of the next, the first and the last beyond it); then compound 1.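

Among the compounds shown here, at the place para to a large group and ortho to two methyl groups, the first measured exchange in this assay is a 1.9-fold higher number from compound 3 to compound 4 (0.27 log units; within the scatter), so replacing methoxy with fluoro, which also removes a hydrogen-bond acceptor and one heavy atom, does not shift the number beyond the scatter. On the amide-type nitrogen, 4-fluoro-3,5-dimethylphenyl in place of 2,5-dimethylphenyl gives a 1.4-fold lower number from compound 2 to compound 4 (0.16 log units; within the scatter), also within the scatter, whereas 4-fluoro-3,5-dimethylphenyl in place of 3,5-dimethylbenzyl gives a 2.9-fold lower number from compound 1 to compound 4 (0.47 log units; beyond the scatter), beyond it, so compound 1 stands apart from compound 4 as it already did from compound 2. Nothing shown here offers an independent measurement that would explain these numbers.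

From the compounds shown here alone, whether a chloro, a hydroxy, an amine or a carboxylic acid at this same place would carry the number beyond the scatter remains open. Going by these compounds, it is also open whether fluoro in place of methoxy would read the same with a 3,5-dimethylbenzyl group on the amide-type nitrogen, as in compound 1, or with the two methyl groups replaced by ethyl groups.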